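Changing the Acyl Group Beside the Urea Linker

The source may report more compounds than this note shows. Statements on the series, on what has been measured and on what is new or still open speak of the compounds shown alone.

Compound 1 `CN(C(=O)NC(=O)c1ccc(F)c(F)c1)c1nc(C(F)(F)F)c(C(=O)N/N=C/c2ccccc2C(F)(F)F)s1` was tested in a functional assay on HepG2 cells (Homo sapiens) for inhibition, read by MTT assay, with a stated time of 72 h (on this read-out higher numbers stand for weaker inhibition and lower numbers for stronger inhibition), where compound 1 gives 10.4 ug/mL. Among the compounds with values here, its only measured neighbour, compound 2 `CN(C(=O)NC(=O)c1ccc(F)c(F)c1)c1nc(C(F)(F)F)c(C(=O)N/N=C/c2cccc(C(F)(F)F)c2)s1`, gives 5.6 ug/mL in this assay. Within the data shown here, the one known step, a 1.9-fold lower number from compound 1 to compound 2 (0.27 log units; within the scatter), leaves those two values indistinguishable. Compound 3 `CN(C(=O)NC(=O)c1ccc(C(F)(F)F)cc1)c1nc(C(F)(F)F)c(C(=O)N/N=C/c2ccccc2C(F)(F)F)s1` differs from compound 1 in a single place: 4-(trifluoromethyl)phenyl in place of 3,4-difluorophenyl on a carbonyl carbon. Among the measured compounds shown here, no measured step touches that carbonyl position; the only step known concerns the group on a carbon with a double bond to nitrogen. The expectation is therefore no step beyond the scatter, a 1.0-fold lower number from compound 1 to compound 3 (0.02 log units; within the scatter). Compound 3 is estimated at 10 ug/mL, with a range from 4 ug/mL to 25 ug/mL.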

Compound 3, half-maximal inhibitory concentration: 3.64 ug/mL
Compound 3: middle estimate off by 2.7-fold (0.44 log units), on the high side, outside the stated range (below it).
By their numbers in this assay, from the lowest: compounds 3, 2 and 1 (each within the scatter of the next, the first and the last beyond it).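

In this assay, within the data shown here, the carbonyl position responds to change: 4-(trifluoromethyl)phenyl in place of 3,4-difluorophenyl gives a 2.9-fold lower number from compound 1 to compound 3 (0.46 log units; beyond the scatter), the only step here beyond the scatter. The earlier step concerned a different position and stayed within the scatter. No available evidence bears on this result.

From the compounds shown here alone, whether the same acyl change would have a similar effect on compound 2 remains open. So does the effect of replacing this aromatic group with a simple methyl group, or of adding an amine or carboxylic acid to the ring.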